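Cyclopentyl for bromo: compound 1 to compound 3

A few compounds are considered here, and "the series" means these few. Any claim that something is new, unique, unknown or untested is made for them only; others in the source may bear on it.

Two compounds carry results in an assay on isolated protein for inhibition of tyrosine-protein kinase receptor UFO (Homo sapiens), read by FRET and Z'-LYTE, with a stated time of 1.5 h; on this read-out higher numbers stand for weaker inhibition and lower numbers for stronger inhibition. Compound 1 `Cc1c(C(=O)Nc2ccc(Oc3ncnc4[nH]cc(-c5ccccc5)c34)c(F)c2)c(=O)c2cc(Br)ccc2n1C` gives 3120 nM in this assay, and this is the only numerical value among the two results shown. Compound 2 `CCc1ccc2c(c1)c(=O)c(C(=O)Nc1ccc(Oc3ccnc(C(N)=O)c3Cl)c(F)c1)c(C)n2C` in this assay gives > 10000 nM, which is a limit of the assay and not a number. That outcome matches (the limit of > 10000 nM in this assay, at which 1 of the 2 values shown sits). Among the measured compounds shown here, no two measured compounds differ in a single place, so no measured step sets a scale for what one structural change does.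

Compound 3 `Cc1c(C(=O)Nc2ccc(Oc3ncnc4[nH]cc(-c5ccccc5)c34)c(F)c2)c(=O)c2cc(C3CCCC3)ccc2n1C` has not been measured. It differs from compound 1 by cyclopentyl in place of bromo on an aromatic carbon. Since compound 1 gives 3120 nM and no measured step of similar kind exists among the compounds shown, the step of a 1.2-fold lower number from compound 1 to compound 3 (0.10 log units; within the scatter) is expected to be modest, not clearly beyond the scatter, with either direction possible. Compound 3 is therefore expected to give about 2500 nM in this assay, within a range from 600 nM to 9000 nM.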

Compound 3, half-maximal inhibitory concentration: 200 nM
Estimate against measurement, compound 3: 13-fold (1.10 log units) above, outside the stated range (below it).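

Notes on the position: in this assay, this aromatic carbon, meta to a fused ring and para to a fused ring, is clearly sensitive to the group it carries, with cyclopentyl in place of bromo giving a 16-fold lower number from compound 1 to compound 3 (1.19 log units; beyond the scatter). Among the compounds shown here, this is the first single-place step, and it is large, so substitution at this carbon can change the read-out well beyond the scatter while the rest of compound 1 stays fixed. The exchange replaces 1 heavy atom with 5 heavy atoms and adds a five-membered non-aromatic ring, with no hydrogen-bond donors, hydrogen-bond acceptors or net charge on either side, and nothing measured here accounts for the size of the step.

Going by these compounds, one step cannot separate the effect of the ring from that of the carbon count or from the loss of bromine, so it remains open whether an open chain such as n-pentyl, a smaller ring such as cyclopropyl or a larger one such as cyclohexyl would match cyclopentyl. Also open, on these data alone, is how this position would respond to a group carrying an amine or a carboxylic acid, as the two groups compared here have no hydrogen-bond donors or acceptors.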